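Replacing quinolin-2-yl on compound 1

The source may report more compounds than this note shows. Statements on the series, on what has been measured and on what is new or still open speak of the compounds shown alone.

Among the compounds with values here, in a functional assay on LNCaP cells (Homo sapiens) for cytotoxicity, read by MTT assay, with a stated time of 72 h (a higher number here means a weaker inhibitor, a lower number a stronger inhibitor), compound 1 (`COc1cc(/C=C/C(=O)/C(=C/c2ccc3ccccc3n2)C(=O)/C=C/C2=C(C)CCCC2(C)C)ccc1O`) gives 8500 nM as the lowest of the two numbers measured so far. Compound 2 (`COc1cc(/C=C/C(O)=C/C(=O)/C=C/C2=C(C)CCCC2(C)C)ccc1O`) gives 20600 nM as the higher number, a gap beyond the usual scatter. Compound 3 (`COc1cc(/C=C(\C(=O)/C=C/C2=C(C)CCCC2(C)C)C(=O)/C=C/c2ccc(O)c(OC)c2)ccc1O`) has not yet been measured. Its difference from compound 1 is 4-hydroxy-3-methoxyphenyl in place of quinolin-2-yl on a double-bonded chain carbon bound to a double-bonded chain carbon and it places 4-hydroxy-3-methoxyphenyl in place of quinolin-2-yl on a double-bonded chain carbon bound to a double-bonded chain carbon. Within the data shown here, no measured pair shows this swap directly, so the evidence is thin. Compound 2 lacks quinolin-2-yl and gives 20600 nM while compound 1 carries it and gives 8500 nM as its number, which hints at a modest rise toward weaker inhibition. In this assay the expected change is a 1.4-fold higher number from compound 1 to compound 3 (0.15 log units; within the scatter) as a small step that may stay within the scatter. For compound 3 the estimate is 12000 nM with an expected range from 4000 nM to 33000 nM across repeated measurements.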

Compound 3, half-maximal inhibitory concentration: 1300 nM
The estimate for compound 3 lay 9.2-fold (0.97 log units) above the measured number; measured number outside the range, below it.
By their numbers in this assay, from the lowest: compound 3; then compound 1; then compound 2.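

In this assay, the place on a double-bonded chain carbon bound to a double-bonded chain carbon turns out to matter: putting 4-hydroxy-3-methoxyphenyl in place of quinolin-2-yl gives a 6.5-fold lower number from compound 1 to compound 3 (0.82 log units; beyond the scatter). Within the data shown here, this is the first direct reading of the swap, and it shows that quinolin-2-yl is not needed here for cytotoxicity in these cells, since the group that enters goes with stronger inhibition. No measurement on hand explains the size or direction of this step.

As far as these compounds go, it remains open whether the hydroxy group, the methoxy group or both within 4-hydroxy-3-methoxyphenyl account for the step, and how a plain phenyl would compare. Also open, from the compounds shown here alone, is what a group of another kind at this place, such as an amine or a carboxylic acid, would do.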